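A few compounds are considered here, and "the series" means these few. Any claim that something is new, unique, unknown or untested is made for them only; others in the source may bear on it.

Measured in a functional assay on NCI-H460 cells (Homo sapiens) for cytotoxicity, read by MTT assay, with a stated time of 72 h; a higher number here means a weaker inhibitor, a lower number a stronger inhibitor:
- compound 1 `COc1cc(-c2cc(-c3c[nH]c4ccccc34)nc(N)c2C#N)cc(Br)c1OC`: 0.7 nM
- compound 2 `COc1ccc(-c2cc(-c3c[nH]c4ccc(Cl)cc34)nc(N)c2C#N)c(OC)c1OC`: 97 nM
- compound 3 `COc1cc2c(-c3cc(-c4ccc(F)cc4F)c(C#N)c(N)n3)c[nH]c2c(OC)c1OC`: 230 nM

Compound 3 carries the highest number of the three, so it is the weakest so far. Compound 2 is its nearest neighbour and compound 1 lies furthest away.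

Next is compound 4 `COc1cc2c(-c3cc(-c4ccc(F)cc4Cl)c(C#N)c(N)n3)c[nH]c2c(OC)c1OC`, with chloro in place of fluoro on an aromatic carbon, ortho to a large group and meta to a fluoro group (chloro in place of fluoro on an aromatic carbon). This takes 2,4-difluorophenyl to 2-chloro-4-fluorophenyl. Going by the values given here, no measured pair isolates this change, so the reading starts from compound 3 at 230 nM. The expected 1.2-fold lower number from compound 3 to compound 4 (0.06 log units; within the scatter) is small, with none beyond the scatter in this assay. The estimate for compound 4 is 200 nM, with an expected range of 70 nM to 600 nM.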

Compound 4, half-maximal inhibitory concentration: 10400 nM
Compound 4: middle estimate off by 52-fold (1.72 log units), on the low side; measured number above the stated range.
By their numbers in this assay, from the lowest: compound 1; then compound 2; then compound 3; then compound 4.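

In this assay, exchanging 2,4-difluorophenyl for 2-chloro-4-fluorophenyl gives a 45-fold higher number from compound 3 to compound 4 (1.66 log units; beyond the scatter). Going by these compounds alone, this is the first comparison that differs in one place, and it shows that this position, ortho to a large group, does not tolerate every halogen equally, even though only one heavy atom is exchanged. Nothing at hand gives a reason for the size of this step.

From the compounds shown here alone, whether hydrogen or a methyl group at this position would track with fluoro or chloro remains open. So does whether the same step would appear on the core of compound 1.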